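From Trifluoromethoxy to Methylsulfonyl in a Urea Series

The source may report more compounds than this note shows. Statements on the series, on what has been measured and on what is new or still open speak of the compounds shown alone.

Three compounds that share a urea linkage have been examined in an assay on isolated protein for inhibition of STE20-like serine/threonine-protein kinase (Homo sapiens), read by thermal shift assay, tested at 10 uM; on this read-out lower numbers stand for weaker stabilisation of the target and higher numbers for stronger stabilisation of the target against heat. Compound 1 `CC(C)(C)c1cc(NC(=O)Nc2cc(C(F)(F)F)cc(C(F)(F)F)c2)n(-c2ccccc2)n1` gives 0 degrees C, compound 2 `Cn1nc(-c2ccccc2)cc1NC(=O)Nc1cc(F)cc(F)c1` gives 0.8 degrees C, and compound 3 `CC(C)(C)c1cc(NC(=O)Nc2ccc(Cl)cc2)n(-c2ccc(OC(F)(F)F)cc2)n1` gives 0.2 degrees C. Each of these numbers lies within the usual scatter of the other two, so compound 3 cannot be separated from compound 1 or from compound 2 on this measurement, and none of the three shows a stabilisation of the target that stands out from noise.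

Compound 4 `CC(C)(C)c1cc(NC(=O)Nc2ccc(Cl)cc2)n(-c2ccc(S(C)(=O)=O)cc2)n1` has not yet been measured. It differs from compound 3 in one place: methylsulfonyl in place of trifluoromethoxy on an aromatic carbon. Among the measured compounds shown here, no pair of measured compounds differs in a comparable way, so the data at hand say nothing about whether such an exchange helps or hurts. What the data do show is that compound 1, compound 2 and compound 3 all give readings in this assay that do not rise beyond the scatter, and a single swap of one group for another on the same ring offers no grounds to expect a departure from that. The step of a number 0.10 degrees C higher from compound 3 to compound 4 (within the scatter) is expected to stay within the scatter, with no clear direction. Compound 4 is therefore estimated at 0.3 degrees C, within a range from -0.7 degrees C to 1.3 degrees C.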

Compound 4, shift of the target's melting temperature: 5.2 degrees C
The estimate for compound 4 lay 4.9 degrees C below the measured number, and the stated range ends below it.
By their numbers in this assay, from the lowest: compounds 1, 3 and 2 (each within the scatter of the next); then compound 4.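

In this assay, placing methylsulfonyl in place of trifluoromethoxy on an aromatic carbon, para to a large group, gives a number 5.0 degrees C higher from compound 3 to compound 4 (beyond the scatter). This is the only step shown between two compounds that differ in one place, and it shows that this position on the ring is not indifferent: with the rest of the molecule unchanged, the group held there decides whether the reading stays within the scatter or clearly rises beyond it. The exchange removes 5 heavy atoms with 1 hydrogen-bond acceptor and brings in 4 heavy atoms with 2 hydrogen-bond acceptors, but no measurement here connects any of these differences to the rise.

The compounds shown do not tell whether the rise is particular to methylsulfonyl or would also appear with another group on the same carbon, such as a sulfonamide, a nitrile or a carboxylic acid. They also leave open whether methylsulfonyl would produce a similar rise on a different core, such as that of compound 2, or with another group in place of the chlorine on the far ring.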